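The source may hold more compounds than are shown below. What is called first, only, known or untested is meant among the compounds shown, and "the series" means these compounds.

In a functional assay on L1210 cells (Mus musculus) for inhibition (on this read-out higher numbers stand for weaker inhibition and lower numbers for stronger inhibition), compound 1 `C#CCN(Cc1ccc2nc(C)nc(O)c2c1)c1ccc(Cl)cc1` gives only a limit, > 4000 nM. Compound 2 `C#CCN(Cc1ccc2nc(C)nc(O)c2c1)c1ccc(C#N)cc1` also gives only a limit, > 5000 nM. Among the compounds with values here, the sole measured step is a step that the two limits leave unreadable from compound 1 to compound 2, so it offers no size to carry forward. Compound 3 `C#CCN(Cc1ccc2nc(C)nc(O)c2c1)c1ccc([N+](=O)[O-])cc1` follows from compound 2 with one change, nitro in place of cyano on an aromatic carbon, para to a large group: nitro in place of cyano on an aromatic carbon. No step beyond the scatter is expected in this assay, and no direction can be read from the data; the estimated change is a step that the limit leaves unreadable from compound 2 to compound 3. Compound 3 is expected at about 6000 nM, with an estimated range of 2500 nM to 15000 nM, and most likely again as a limit.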

Compound 3, half-maximal inhibitory concentration: 4700 nM
The estimate for compound 3 lay 1.3-fold (0.11 log units) above the measured number, and the stated range covers the measured number.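

In this assay compound 3 gives 4700 nM, a true number at this position, para to a large group. Compound 1 and compound 2 gave only limits there. With nitro in place of cyano on an aromatic carbon, the result is an at least 1.0-fold lower number from compound 2 to compound 3 (0.02 log units; that floor lies within the scatter), which establishes no step beyond the scatter. Compound 2 stands at a limit, which leaves this comparison with only a floor: the limit of > 5000 nM in this assay, at which 1 of the 3 values shown sits.

The steps from compound 1 cannot be read. From the compounds shown here alone, whether an amine or a carboxylic acid at this position would give a clearly lower number stays open.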